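Hydroxy and methoxy exchange from compound 1 to compound 4

This account rests on a few compounds, and the source may have more. Where it says the series, first, only, none or still open, it means among the compounds named here.

In a functional assay on MCF7 cells (Homo sapiens) for cytotoxicity, read by MTT assay, with a stated time of 48 h (on this read-out higher numbers stand for weaker inhibition and lower numbers for stronger inhibition), compound 1 (`COc1ccc2c(c1)nc(/C=C/C(=O)/C=C/c1ccc(O)c(OC)c1)n2C`) gives 3900 nM and compound 2 (`COc1cc(/C=C/C(=O)/C=C/c2nc3cc(Cl)ccc3n2C)ccc1O`) gives 4400 nM while compound 3 (`COc1cc(/C=C/C(=O)/C=C/c2nc3cc([N+](=O)[O-])ccc3n2C)ccc1O`) gives 3700 nM on the same read-out. The three numbers form a single cluster, and compound 1 lies inside it with no separation from either of the others.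

Compound 4 (`COc1ccc2c(c1)nc(/C=C/C(=O)/C=C/c1ccc(OC)c(O)c1)n2C`) keeps the core of compound 1 and differs in one place: 3-hydroxy-4-methoxyphenyl in place of 4-hydroxy-3-methoxyphenyl on a double-bonded chain carbon bound to a double-bonded chain carbon (the two have the same atoms, joined differently).

The measured steps are a 1.1-fold higher number from compound 1 to compound 2 (0.05 log units; within the scatter) for chloro in place of methoxy, a 1.1-fold lower number from compound 1 to compound 3 (0.02 log units; within the scatter) for nitro in place of methoxy and a 1.2-fold lower number from compound 2 to compound 3 (0.08 log units; within the scatter) for nitro in place of chloro, each on an aromatic carbon and each within the scatter. None of them touches the 4-hydroxy-3-methoxyphenyl group, so they bear on this change only indirectly. Going by the values given here, no measured compound carries the 3-hydroxy-4-methoxyphenyl group, and the data give no direction for the exchange.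

In this assay the expected step is a 1.0-fold higher number from compound 1 to compound 4 (0.01 log units; within the scatter) and thus none beyond the scatter, though the untested exchange keeps the range wide. The estimated value for compound 4 is 4000 nM (expected range 1500 nM to 10000 nM).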

Compound 4, half-maximal inhibitory concentration: 3700 nM
Compound 4: middle estimate off by 1.1-fold (0.03 log units), on the high side; the range from low to high includes it.
By their numbers in this assay, from the lowest: compounds 3, 4, 1 and 2 (each within the scatter of the next).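

Going by these compounds alone, the exchange gives the first reading at the group on the double-bonded chain carbon, which stayed unchanged across the earlier steps on the aromatic carbon of the core. In this assay, moving from 4-hydroxy-3-methoxyphenyl to 3-hydroxy-4-methoxyphenyl gives a 1.1-fold lower number from compound 1 to compound 4 (0.02 log units; within the scatter) and so does not separate the two arrangements of the same atoms, at least on the core of compound 1. No supporting measurement is available to explain this result.

Open is whether this position responds to anything beyond an exchange of hydroxy and methoxy, such as an amine or a carboxylic acid in place of the hydroxy, or a longer chain such as ethoxy in place of the methoxy, since both phenyl groups shown carry the same atoms. Also open, on these data alone, is whether the 3-hydroxy-4-methoxyphenyl group would read the same alongside the chloro of compound 2 or the nitro of compound 3, as the exchange has been read only on the core of compound 1 and with this one cell read-out.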